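The compounds below may be only part of what the source reports. "The series", "measured", "known", "first", "only" and "open" are said of these compounds alone.

Measured in a functional assay on HT-29 cells (Homo sapiens) for cytotoxicity, read by MTT assay, with a stated time of 48 h; a higher number here means a weaker inhibitor, a lower number a stronger inhibitor:
- compound 1 `CCCC1C(C(=O)OC)=C(C)NC(C)=C1C(=O)OC`: "not active" (no number reported)
- compound 2 `COC(=O)C1=C(C)NC(C)=C(C(=O)OC)C1c1ccccc1`: "not active" (no number reported)
- compound 3 `COC(=O)C1=C(C)NC(C)=C(C(=O)OC)C1c1ccc(OC)cc1`: 452000 nM

Compound 3 is the only one of these with a number in this assay, at 452000 nM, while the other two gave none. Compound 4 `COC(=O)C1=C(C)NC(C)=C(C(=O)OC)C1c1ccc(Cl)cc1` keeps the shared core and carries chloro in place of methoxy on an aromatic carbon, para to a large group (chloro in place of methoxy on an aromatic carbon). Among the compounds with values here, no step between measured compounds is available to guide the size of this change. A step no larger than the scatter is expected, leaning if anything toward a lower number, and the estimated step is a 1.5-fold lower number from compound 3 to compound 4 (0.18 log units; within the scatter). Compound 4 is expected to read 300000 nM, with an estimated range of 100000 nM to 800000 nM.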

Compound 4, half-maximal inhibitory concentration: "not active" (no number reported)
Compound 4: no number reported; no gap can be computed for the estimate.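

In this assay, within the data shown here, compound 4 gave no number, so no step from compound 3 to compound 4 can be read. No measured evidence bears on this result. The compounds shown leave open how far 4-methoxyphenyl to 4-chlorophenyl shifts the read-out.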